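The compounds below may be only part of what the source reports. "The series", "measured", "known", "first", "only" and "open" are said of these compounds alone.

Going by the values given here, in a functional assay on U-937 cells (Homo sapiens) for cytotoxicity, read by CCK-8 assay, with a stated time of 72 h (on this read-out higher numbers stand for weaker inhibition and lower numbers for stronger inhibition), compound 2 `C=CCn1c(=O)/c(=C\c2cccc(Br)c2)[nH]c(=O)/c1=C\c1ccccc1OC` gives 1100 nM, the lowest of the two numbers measured so far. Among the compounds with values here, its nearest neighbour is compound 1 `C=CCn1c(=O)/c(=C\c2cc(Br)ccc2F)[nH]c(=O)/c1=C\c1ccccc1OC`, which in this assay gives 4700 nM; the only step seen, a 4.3-fold lower number from compound 1 to compound 2 (0.63 log units; beyond the scatter), comes from a hydrogen in place of fluoro on an aromatic carbon and is of modest size. Compound 3 `C=CCn1c(=O)/c(=C\c2cc(F)ccc2C)[nH]c(=O)/c1=C\c1ccccc1OC` has not yet been measured; it differs from compound 2 by 5-fluoro-2-methylphenyl in place of 3-bromophenyl on a double-bonded chain carbon bound to an aromatic carbon. Within the data shown here, this change moves the aromatic substituents back toward a pattern resembling compound 1, so the single step of a 4.3-fold lower number from compound 1 to compound 2 (0.63 log units; beyond the scatter) bears on it, though it is not the same change, and the direction could only be read as a loose hint toward a higher number. A modest rise is therefore expected, as a 3.2-fold higher number from compound 2 to compound 3 (0.50 log units; beyond the scatter), with wide uncertainty. Compound 3 is estimated at 3500 nM, within a range from 1200 nM to 10000 nM.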

Compound 3, half-maximal inhibitory concentration: 1000 nM
Compound 3: middle estimate off by 3.5-fold (0.54 log units), on the high side; the whole stated range lies above it.
By their numbers in this assay, from the lowest: compounds 3 and 2 (each within the scatter of the next); then compound 1.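

In this assay, putting 5-fluoro-2-methylphenyl in place of 3-bromophenyl on a double-bonded chain carbon bound to an aromatic carbon gives a 1.1-fold lower number from compound 2 to compound 3 (0.04 log units; within the scatter), so this assay does not separate the two groups, even though they carry different substituents. Set against the 5-bromo-2-fluorophenyl group at the same place, the same new group gives a 4.7-fold lower number from compound 1 to compound 3 (0.67 log units; beyond the scatter), which shows that a phenyl group with two substituents does not by itself bring the higher number seen for compound 1. Nothing measured here explains why these groups compare as they do.

Going by these compounds, whether a phenyl group bearing an amine or a carboxylic acid would fit this pattern remains open. So does the effect of changes elsewhere, since the rest of the molecule is the same in all three compounds.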